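A few compounds are considered here, and "the series" means these few. Any claim that something is new, unique, unknown or untested is made for them only; others in the source may bear on it.

Of the compounds shown here, three built on a shared core have been measured in a functional assay on K562 cells (Homo sapiens) for inhibition; a higher number here means a weaker inhibitor, a lower number a stronger inhibitor. Compound 1 `O=C1C=CC(OCC(F)(F)F)N1c1cc(Cl)cc(Cl)c1` gives 1640 nM in this assay, and compound 2 `O=C1C=CC(OCC(F)(F)F)N1c1cc(F)cc(F)c1` gives 520 nM. Compound 3 `Cc1ccc(N2C(=O)C=CC2OCC(F)(F)F)cc1` gives 7140 nM, the highest of the three numbers; compound 1 is its nearest neighbour and compound 2 its furthest, and both gaps lie beyond the scatter. Compound 4 `O=C1C=CC(OCC(F)(F)F)N1c1ccc([N+](=O)[O-])cc1` has not yet been measured. It differs from compound 3 by nitro in place of methyl on an aromatic carbon. Among the compounds with values here, no pair of measured compounds differs in one place only, so no measured step describes this change, and the two halogen-bearing compounds, compound 1 and compound 2, both sit at lower numbers than compound 3 without telling how a nitro group would behave. A moderate step toward a lower number is expected in this assay, though with wide uncertainty. Compound 4 is therefore estimated at 3000 nM, within a range from 800 nM to 12000 nM. This estimate means an expected step of a 2.4-fold lower number from compound 3 to compound 4 (0.38 log units; beyond the scatter).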

Compound 4, half-maximal inhibitory concentration: 1530 nM
Beside the measured number, compound 4's estimate is 2.0-fold (0.29 log units) above it, and the stated range covers the measured number.
By their numbers in this assay, from the lowest: compound 2; then compounds 4 and 1 (each within the scatter of the next); then compound 3.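

In this assay nitro in place of methyl on an aromatic carbon, para to a large group, brings a 4.7-fold lower number from compound 3 to compound 4 (0.67 log units; beyond the scatter) and gives the only single-place change among these compounds. It shows that the number responds to what sits at this position, since this one exchange moves it beyond the scatter while the rest of the structure stays the same. No measured information accounts for the direction or size of this step. Going by these compounds, whether an amine, a carboxylic acid or a nitrile at this same position would also give a lower number than methyl remains open. Also open, on these data alone, is whether nitro would give a similar step if it stood elsewhere on the six-membered aromatic ring, or if the trifluoroethoxy-bearing part of the shared core were changed at the same time.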